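Amide Formation on the Amine and Cytotoxicity

This account rests on a few compounds, and the source may have more. Where it says the series, first, only, none or still open, it means among the compounds named here.

The measured compounds:
compound 1, `CN1CCN(CC(=O)OC2CC3(N(C)C)CC(c4ccccc4)C2C(c2ccccc2)C3)CC1`: 39900 nM
compound 2, `CN(C)C12CC(N)C(C(c3ccccc3)C1)C(c1ccccc1)C2`: 40900 nM
compound 3, `NC1CC2(N3CCCC3)CC(c3ccccc3)C1C(c1ccccc1)C2`: 38100 nM

In an ADME assay on L6 cells (Rattus norvegicus) for cytotoxicity, read by resazurin assay, with a stated time of 72 h (on this read-out lower numbers stand for stronger inhibition and higher numbers for weaker inhibition), compound 2 cannot be told apart from its neighbours: the step of a 1.0-fold higher number from compound 1 to compound 2 (0.01 log units; within the scatter) and the step of a 1.1-fold lower number from compound 2 to compound 3 (0.03 log units; within the scatter) both sit inside the scatter. Compound 4, `CN1CCN(CCC(=O)NC2CC3(N(C)C)CC(c4ccccc4)C2C(c2ccccc2)C3)CC1`, differs from compound 2 by (2-(4-methylpiperazin-1-yl)ethyl)carbonyl in place of hydrogen on an amine nitrogen. Within the data shown here, the only measured step that bears on it is the one from compound 1 to compound 2, where a group carrying the same 4-methylpiperazin-1-yl unit left and amino entered, with a 1.0-fold higher number from compound 1 to compound 2 (0.01 log units; within the scatter). Reinstating a related unit is therefore expected to move the number by no more than the scatter, so compound 4 is estimated at 40000 nM, between 20000 nM and 80000 nM, a step of a 1.0-fold lower number from compound 2 to compound 4 (0.01 log units; within the scatter).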

Compound 4, half-maximal inhibitory concentration: 95000 nM
Beside the measured number, compound 4's estimate is 2.4-fold (0.38 log units) below it; the whole stated range lies below it.
By their numbers in this assay, from the lowest: compounds 3, 1 and 2 (each within the scatter of the next); then compound 4.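

In this assay placing (2-(4-methylpiperazin-1-yl)ethyl)carbonyl on the amine nitrogen gives a 2.3-fold higher number from compound 2 to compound 4 (0.37 log units; beyond the scatter) as a modest step toward weaker inhibition. This is the first step among these compounds to pass the scatter, so a change on this amine nitrogen can move the number, which the earlier steps did not show. Nothing at hand accounts for the shift. From the compounds shown here alone, it remains open whether the carbonyl or the 4-methylpiperazin-1-yl unit carries the step; an acetyl group on the same nitrogen, or a morpholine in place of the piperazine, would separate the two.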